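This account rests on a few compounds, and the source may have more. Where it says the series, first, only, none or still open, it means among the compounds named here.

Measured compounds:
compound 1 `CN(C)CCCCCSC1=Nc2ccccc2C(CC(=O)NCc2ccccc2)N1c1ccc(-c2ccc(F)cc2)cc1`, 17600 nM in a functional assay on A549 cells (Homo sapiens) for cytotoxicity, read by MTT assay, with a stated time of 48 h; on this read-out higher numbers stand for weaker inhibition and lower numbers for stronger inhibition
compound 2 `O=C(CC1c2ccccc2N=C(SCCCCCN2CCCC2)N1c1ccc(-c2ccc(F)cc2)cc1)NCc1ccc(F)cc1`, 12600 nM in this assay

Both compounds were tested in this assay. Compound 1 gives 17600 nM in this assay, and compound 2 gives 12600 nM in this assay. Compound 2 and compound 1 stand within the scatter of each other, so on the two numbers shown compound 2 is level with compound 1 rather than separated from it.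

Compound 3 `O=C(CC1c2ccccc2N=C(SCCCCCN2CCCC2)N1c1ccc(-c2ccc(F)cc2)cc1)NCc1ccccc1` is not yet measured. It differs from compound 2 in one place: hydrogen in place of fluoro on an aromatic carbon, which is hydrogen in place of fluoro on an aromatic carbon. Among the compounds with values here, no pair of measured compounds shows this change alone, so the direction of the step cannot be read from a measured step. Within the data shown here, compound 1, which carries an unsubstituted benzyl group, and compound 2, which carries a fluorinated one, lie within the scatter of each other, and that is the only guide available.

Compound 3 is therefore expected to give about 14000 nM in this assay, with a range from 7000 nM to 30000 nM. The step that this estimate means, a 1.1-fold higher number from compound 2 to compound 3 (0.05 log units; within the scatter), is expected to stay within the scatter, in no clear direction.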

Compound 3, half-maximal inhibitory concentration: 17800 nM
Compound 3: middle estimate off by 1.3-fold (0.10 log units), on the low side; the measured number falls inside the stated range.
By their numbers in this assay, from the lowest: compounds 2, 1 and 3 (each within the scatter of the next).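

In this assay, the swap at this position, hydrogen in place of fluoro on an aromatic carbon of the benzyl group, gives a 1.4-fold higher number from compound 2 to compound 3 (0.15 log units; within the scatter) and so supplies the measured step that was missing before. It shows that compound 2 and compound 3 cannot be told apart on these numbers, so at this position the 4-fluorobenzyl and benzyl groups stand level in this cytotoxicity read-out. The second step shows the same for the other end of the molecule: pyrrolidin-1-yl in place of dimethylamino on the saturated chain gives a 1.0-fold higher number from compound 1 to compound 3 (0.00 log units; within the scatter) and so leaves that pair level as well.

Still open, as far as these compounds go, is whether any other group would move the number beyond the scatter, for example a chlorine, a methoxy group or a carboxylic acid in place of the fluoro, or a morpholine or a primary amine at the end of the chain, or a longer chain. Nothing shown here bears on why these two changes leave the numbers level.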